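A Pyridin-2-yl Group Takes the Place of 1,3-Thiazol-2-yl

The source may report more compounds than this note shows. Statements on the series, on what has been measured and on what is new or still open speak of the compounds shown alone.

In a functional assay on MCF7 cells (Homo sapiens) for inhibition, with a stated time of 96 h (a higher number here means a weaker inhibitor, a lower number a stronger inhibitor), compound 1 (`COc1cc(C(=O)c2cn(-c3cccc(C)c3)cc2-c2ccco2)cc(OC)c1OC`) gives 23 nM while compound 2 (`COc1cc(C(=O)c2cn(-c3cccc(C)c3)cc2-c2nccs2)cc(OC)c1OC`) gives 20 nM and compound 3 (`COc1cc(C(=O)c2cn(-c3ccc(F)cc3)cc2-c2nccs2)cc(OC)c1OC`) gives 22 nM on the same read-out. Compound 2 therefore stands within the scatter of both other compounds, and its number cannot be set apart from theirs. The open question concerns compound 4 (`COc1cc(C(=O)c2cn(-c3cccc(C)c3)cc2-c2ccccn2)cc(OC)c1OC`), which carries pyridin-2-yl in place of 1,3-thiazol-2-yl on an aromatic carbon.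

Among the measured compounds shown here, two measured steps bear on this change. The more relevant one, a 1.2-fold lower number from compound 1 to compound 2 (0.06 log units; within the scatter), exchanges furan-2-yl for 1,3-thiazol-2-yl at the same place and stays within the scatter. The other, a 1.1-fold higher number from compound 2 to compound 3 (0.04 log units; within the scatter), puts 4-fluorophenyl in place of 3-methylphenyl on an aromatic nitrogen, also within the scatter, but it says nothing directly about the carbon in question. Pyridin-2-yl, with its six-membered aromatic ring, has no measured precedent at this place, so the range must stay wide. The expected change is a 1.3-fold higher number from compound 2 to compound 4 (0.11 log units; within the scatter), with no direction expected beyond the scatter. For compound 4 the estimate is 26 nM, with an expected range from 9 nM to 75 nM in this assay once measured.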

Compound 4, half-maximal inhibitory concentration: 140 nM
The estimate for compound 4 lay 5.4-fold (0.73 log units) below the measured number; the whole stated range lies below it.
By their numbers in this assay, from the lowest: compounds 2, 3 and 1 (each within the scatter of the next); then compound 4.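

The carbon that seemed indifferent to its substituent while only furan-2-yl and 1,3-thiazol-2-yl were compared turns out to be sensitive to the group it carries: in this assay, pyridin-2-yl gives a 7.0-fold higher number from compound 2 to compound 4 (0.85 log units; beyond the scatter) and, measured against furan-2-yl, a 6.1-fold higher number from compound 1 to compound 4 (0.78 log units; beyond the scatter). Thus the agreement between compound 1 and compound 2 does not extend to every aromatic group at this place, and compound 4 is the weakest inhibitor of the four, with both of its listed steps beyond the scatter. The change from compound 2 to compound 4 replaces a five-membered aromatic ring with 2 hetero atoms by a six-membered aromatic ring with 1 hetero atom, and nothing available explains why the number rises.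

With a single six-membered example, the compounds shown cannot separate ring size from the number or identity of the hetero atoms, and a phenyl or pyridin-3-yl group at this carbon would help to tell these apart. Going by these compounds, it also remains open whether pyridin-2-yl would give a similar step with the 4-fluorophenyl group of compound 3 on the ring nitrogen.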